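A few compounds are considered here, and "the series" means these few. Any claim that something is new, unique, unknown or untested is made for them only; others in the source may bear on it.

In a functional assay on PC-3 cells (Homo sapiens) for cytotoxicity, read by MTT assay, with a stated time of 72 h (a higher number here means a weaker inhibitor, a lower number a stronger inhibitor), compound 3 (`COc1cc2ncnc(Nc3ccc(F)c(Cl)c3)c2cc1NC(=O)N/N=C/c1ccc([N+](=O)[O-])cc1`) gives 32400 nM, within the scatter of compound 1 (`O=C(N/N=C/c1ccc([N+](=O)[O-])cc1)Nc1cc2c(Nc3ccc(F)c(Cl)c3)ncnc2cc1O[C@H]1CCOC1`) at 33500 nM, while compound 2 (`O=C(N/N=C/c1ccc(O)cc1)Nc1cc2c(Nc3ccc(F)c(Cl)c3)ncnc2cc1O[C@H]1CCOC1`) gives a clearly lower 4890 nM. Compound 4 (`COc1cc2ncnc(Nc3ccc(F)c(Cl)c3)c2cc1NC(=O)N/N=C/c1ccc(O)cc1O`) alters one group of compound 3: 2,4-dihydroxyphenyl in place of 4-nitrophenyl on a carbon with a double bond to nitrogen. Among the compounds with values here, two measured steps bear on this. Hydroxy in place of nitro gave a 6.9-fold lower number from compound 1 to compound 2 (0.84 log units; beyond the scatter), the closest precedent. Methyl in place of oxolan-3-yl gave a 1.0-fold lower number from compound 1 to compound 3 (0.01 log units; within the scatter), so the methyl of compound 3 gives no reason to expect a different outcome. Within the data shown here, no measured compound carries 2,4-dihydroxyphenyl, so a similar step toward a lower number in this assay is only an expectation. The estimated step is a 6.5-fold lower number from compound 3 to compound 4 (0.81 log units; beyond the scatter). For compound 4 the expected value is 5000 nM, with an estimated range from 1800 nM to 14000 nM.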

Compound 4, half-maximal inhibitory concentration: 29500 nM
Compound 4: the middle estimate sits 5.9-fold (0.77 log units) below what was measured; measured number above the stated range.
By their numbers in this assay, from the lowest: compound 2; then compounds 4, 3 and 1 (each within the scatter of the next).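

In this assay, the change gives a 1.1-fold lower number from compound 3 to compound 4 (0.04 log units; within the scatter), so 2,4-dihydroxyphenyl and 4-nitrophenyl cannot be told apart on a carbon with a double bond to nitrogen in this methyl-bearing series. The earlier hydroxy-for-nitro step, a 6.9-fold lower number from compound 1 to compound 2 (0.84 log units; beyond the scatter), therefore does not carry over to this different replacement. No measurement offered here explains why the two steps differ. The compounds shown leave open whether the second hydroxy or the methyl in place of oxolan-3-yl separates the two outcomes. They also leave open how an amine or a carboxylic acid on that ring would read.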